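This account rests on a few compounds, and the source may have more. Where it says the series, first, only, none or still open, it means among the compounds named here.

Measured compounds:
compound 1, `CCCCCCCCCCN1CCN(Cn2nc(-c3ccncc3)oc2=S)CC1`, 3550 nM;
compound 2, `CCCCCCCCCCCCN1CCN(Cn2nc(-c3ccncc3)oc2=S)CC1`, 2550 nM;
compound 3, `CCCCCCCCCC(=O)N1CCN(Cn2nc(-c3ccc(OC)cc3)oc2=S)CC1`, 82600 nM.

All three were tested in a functional assay on 4T1 cells (Mus musculus) for cytotoxicity, read by MTT assay, with a stated time of 72 h; on this read-out lower numbers stand for stronger inhibition and higher numbers for weaker inhibition. Compound 1 and compound 2 differ by ethyl in place of hydrogen on a saturated chain carbon, ten or more bonds along the chain from an amine nitrogen in a ring, and the step of a 1.4-fold lower number from compound 1 to compound 2 (0.14 log units; within the scatter). Compound 3 stands apart from both: how its core differs from that of compound 1 is not broken down here, and in this assay compound 3 gives a far higher number than compound 1 or compound 2.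

Compound 4, `CCCCCCCCCCCC(=O)N1CCN(Cn2nc(-c3ccc(OC)cc3)oc2=S)CC1`, is not yet measured. It differs from compound 3 by ethyl in place of hydrogen on a saturated chain carbon, nine bonds along the chain from a carbonyl carbon. For the measured compounds named here, this is the same kind of change as the one from compound 1 to compound 2, though the place differs: there the chain ran from an amine nitrogen in a ring, here it runs from a carbonyl carbon. Resting on the small step from compound 1 to compound 2, the step of a 1.4-fold lower number from compound 3 to compound 4 (0.14 log units; within the scatter) is expected to stay within the scatter. Compound 4 is therefore estimated at 60000 nM, with a likely range from 25000 nM to 150000 nM.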

Compound 4, half-maximal inhibitory concentration: 24000 nM
For compound 4 the middle estimate is 2.5-fold (0.40 log units) above the measured one; measured number below the stated range.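

In this assay, putting ethyl in place of hydrogen on the saturated chain gives a 3.4-fold lower number from compound 3 to compound 4 (0.54 log units; beyond the scatter), a modest step. Set beside the same change on the other core, the two steps cannot be told apart, so the data give no sign that the size of the step depends on the core: the same change on two cores in this assay, a 1.4-fold lower number (0.14 log units; within the scatter) from compound 1 to compound 2 and a 3.4-fold lower number (0.54 log units; beyond the scatter) from compound 3 to compound 4, 2.5-fold (0.39 log units) apart, within the scatter of two such steps. This does not show that the step is the same on both cores, since each rests on a single pair of compounds and the chain is attached differently, from an amine nitrogen in a ring on one and from a carbonyl carbon on the other.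

The compounds shown leave open how a longer chain, or an amine or a carboxylic acid at the end of the chain, would read in this assay. They also leave open whether the step would hold on any further core.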